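The compounds below may be only part of what the source reports. "The series", "measured", "known", "first", "only" and "open" are said of these compounds alone.

Compound 1 `O=C(CN1CCC(c2ccc(F)cc2)(c2ccc(F)cc2)C1=O)N1CCN(Cc2cccc(C(F)(F)F)c2)CC1`: in a physicochemical assay for solubility, at pH 7 (on this read-out lower numbers stand for lower solubility and higher numbers for higher solubility), compound 1 gives < 25000 nM, which is a limit of the assay and not a number.
Compound 2 `O=C(CN1CCCC(c2ccccc2)(c2ccccc2)C1=O)N1CCN(Cc2ccc(Cl)cc2Cl)CC1`: in this assay compound 2 gives < 25000 nM, again a limit of the assay rather than a number.

Compound 2 therefore has no exact reading in this assay; it sits at the limit of < 25000 nM in this assay, at which 2 of the 2 values shown sit, and compound 1 shares that limit, so the two cannot be placed in any order. Compound 3 `O=C(CN1CCCC(c2ccccc2)(c2ccccc2)C1=O)N1CCN(Cc2ccc(C(F)(F)F)cc2)CC1` has not yet been measured. It differs from compound 2 in one place: 4-(trifluoromethyl)phenyl in place of 2,4-dichlorophenyl on a saturated chain carbon bound to an amine nitrogen in a ring. Among the compounds with values here, no step between two measured compounds is available to show how such a change affects this assay, so the expectation rests on the limit alone. Compound 3 is expected to stay near that limit, with a step that the limit leaves unreadable from compound 2 to compound 3 that is not expected to exceed the usual scatter. The estimated solubility of compound 3 in this assay is 10000 nM, within a range from 2000 nM to 25000 nM.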

Compound 3, solubility: < 25000 nM
Compound 3: no number, only a limit (the forecaster's own chance of this, stated with the estimate: 75%); the middle value lies beyond the limit too.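

Compound 2 and compound 3 both give a limit of the assay rather than a number, so no step between them can be read in this assay: the limit of < 25000 nM in this assay, at which 3 of the 3 values shown sit.

The compounds shown leave open how far each true value lies from that limit, and whether 4-(trifluoromethyl)phenyl in place of 2,4-dichlorophenyl changes the read-out at all.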